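This account rests on a few compounds, and the source may have more. Where it says the series, first, only, none or still open, it means among the compounds named here.

Of the compounds shown here, three sharing one core have been tested in a functional assay on HeLa cells (Homo sapiens) for antiproliferative activity, read by sulforhodamine B assay, with a stated time of 72 h; a higher number here means a weaker inhibitor, a lower number a stronger inhibitor. Compound 1 `COc1ccccc1NC(=S)N/N=C/c1ccc2ccccc2n1`, with a 2-methoxyphenyl group on the amide-type nitrogen, gives > 100000 nM, which is a limit and not a number. Compound 2 `S=C(N/N=C/c1ccc2ccccc2n1)Nc1cccc(Br)c1`, with a 3-bromophenyl group there, gives 70000 nM. Compound 3 `S=C(N/N=C/c1ccc2ccccc2n1)Nc1ccccc1Br`, with a 2-bromophenyl group, gives > 100000 nM, again a limit, and so stands at the limit of > 100000 nM in this assay, at which 2 of the 3 values shown sit.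

Compound 4 `COc1ccc(NC(=S)N/N=C/c2ccc3ccccc3n2)cc1` has not yet been measured. It carries 4-methoxyphenyl in place of 2-bromophenyl on an amide-type nitrogen, a change counted as 4-methoxyphenyl in place of 2-bromophenyl on an amide-type nitrogen.

Within the data shown here, three measured steps bear on this change. Putting 2-bromophenyl in place of 3-bromophenyl gave an at least 1.4-fold higher number from compound 2 to compound 3 (0.15 log units; that floor lies within the scatter). Putting 3-bromophenyl in place of 2-methoxyphenyl gave an at least 1.4-fold lower number from compound 1 to compound 2 (0.15 log units; that floor lies within the scatter). Bromo in place of methoxy gave a step that the two limits leave unreadable from compound 1 to compound 3. None of these shows a change beyond the scatter, so no step beyond the scatter is expected in this assay, and no direction can be read. A report of only a limit is as likely as a number.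

The estimated step is an at least 1.1-fold lower number from compound 3 to compound 4 (0.04 log units; that floor lies within the scatter). For compound 4 the expected value is 90000 nM, with an estimated range from 30000 nM to 200000 nM.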

Compound 4, half-maximal inhibitory concentration: 72600 nM
Estimate against measurement, compound 4: 1.2-fold (0.09 log units) above; the range from low to high includes it.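

Among these compounds, with 4-methoxyphenyl on the amide-type nitrogen, compound 4 gives the first actual number for a methoxyphenyl group in this assay, and the comparison with the 3-bromophenyl group shows a 1.0-fold higher number from compound 2 to compound 4 (0.02 log units; within the scatter), so exchanging these two groups leaves the value unchanged within the scatter. The comparisons with the two compounds reported only as limits give an at least 1.3-fold lower number from compound 3 to compound 4 (0.13 log units; that floor lies within the scatter) and an at least 1.3-fold lower number from compound 1 to compound 4 (0.13 log units; that floor lies within the scatter), and as both floors lie within the scatter, neither establishes a real gain over the 2-bromophenyl or 2-methoxyphenyl group. Among these four compounds, compound 2 and compound 4 give numbers, whereas compound 1 and compound 3, the two with 2-substituted phenyl groups, give only limits, and no compound shown goes against this split: the limit of > 100000 nM in this assay, at which 2 of the 4 values shown sit.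

From the compounds shown here alone, the true distance of compound 1 and compound 3 from the measured compounds remains open, and the steps that run between two limits cannot be read. Going by these compounds, it also remains open whether an aminophenyl group, a carboxyphenyl group or a longer chain on the amide-type nitrogen would move the value beyond the scatter.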